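Moving the ring nitrogen in a bicyclic urea series

A few compounds are considered here, and "the series" means these few. Any claim that something is new, unique, unknown or untested is made for them only; others in the source may bear on it.

Compound 2 `CC1CCN(c2nc(C(F)(F)F)ccc2CNC(=O)Nc2ccc3ccncc3c2)CC1` gives 8.4 nM in an assay on isolated protein for antagonist activity at transient receptor potential cation channel subfamily V member 1 (Homo sapiens), read by FLIPR (on this read-out lower numbers stand for stronger inhibition and higher numbers for weaker inhibition), the lowest of the two numbers shown; compound 3 `CC1CCN(c2nc(C(F)(F)F)ccc2CNC(=O)Nc2cccc3cccnc23)CC1` gives 91.6 nM, and compound 1 `CC1CCN(c2nc(C(F)(F)F)ccc2CNC(=O)Nc2ccc3ccccc3n2)CC1` gives "not active" (no number reported). The step of an 11-fold higher number from compound 2 to compound 3 (1.04 log units; beyond the scatter) shows that exchanging one bicyclic group for another on this amide-type nitrogen can shift the read-out substantially. Within the data shown here, compound 4 `CC1CCN(c2nc(C(F)(F)F)ccc2CNC(=O)Nc2cccc3ncccc23)CC1` differs from compound 2 by quinolin-5-yl in place of isoquinolin-7-yl on an amide-type nitrogen, so that step is the only guide, and its direction for this new group is unknown. Among the measured compounds shown here, the account therefore expects a step of a 3.0-fold higher number from compound 2 to compound 4 (0.47 log units; beyond the scatter), towards a somewhat higher number, since the one known change to a quinolinyl group weakened inhibition. Compound 4 is estimated at 25 nM, within 6 nM to 110 nM.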

Compound 4, inhibition constant: 0.7 nM
Beside the measured number, compound 4's estimate is 36-fold (1.55 log units) above it; the measured number lies below the stated range.
By their numbers in this assay, from the lowest: compound 4; then compound 2; then compound 3.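

In this assay, this position on the amide-type nitrogen responds to how the same atoms are joined, not merely to the change from an isoquinolinyl to a quinolinyl group, with a 12-fold lower number from compound 2 to compound 4 (1.08 log units; beyond the scatter). The two quinolinyl groups also differ widely, with a 130-fold lower number from compound 3 to compound 4 (2.12 log units; beyond the scatter), so the weakening seen with quinolin-8-yl does not carry over to quinolin-5-yl. Nothing available here bears on what lies behind these steps. Still open, on these data alone, is whether quinolin-5-yl would keep this number with a fluorine or methoxy group added, and whether a naphthalen-1-yl group, which has no ring nitrogen, would match it.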